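A few compounds are considered here, and "the series" means these few. Any claim that something is new, unique, unknown or untested is made for them only; others in the source may bear on it.

In a functional assay on A549 cells (Homo sapiens) for cytotoxicity, read by sulforhodamine B assay, with a stated time of 48 h (on this read-out higher numbers stand for weaker inhibition and lower numbers for stronger inhibition), compound 1 `CO[C@@H]1CC=C2NN(c3ccc(C)cc3)C(=O)CC[C@]2(c2ccccc2)O1` gives 3170 nM. Compound 2 `CO[C@@H]1CC=C2NN(c3ccc([N+](=O)[O-])cc3)C(=O)CC[C@]2(c2ccccc2)O1` differs from compound 1 by nitro in place of methyl on an aromatic carbon and in this assay compound 2 gives 9490 nM, the change making a 3.0-fold higher number from compound 1 to compound 2 (0.48 log units; beyond the scatter). Compound 3 `CO[C@@H]1CC=C2N(c3ccc(C)cc3)C(=O)C[C@]2(c2ccccc2)O1` carries another core; the difference between the two cores is not broken down here. In this assay compound 3 gives 3920 nM, and its value and that of compound 1 lie within the scatter of each other. Compound 4 `CO[C@@H]1CC=C2N(c3ccc([N+](=O)[O-])cc3)C(=O)C[C@]2(c2ccccc2)O1` is not yet measured; it differs from compound 3 by nitro in place of methyl on an aromatic carbon, the same change as between compound 1 and compound 2, at the same place. For the measured compounds named here, a step of similar size is expected, a 2.8-fold higher number from compound 3 to compound 4 (0.45 log units; beyond the scatter), because a 3.0-fold higher number from compound 1 to compound 2 (0.48 log units; beyond the scatter) is the only earlier instance of the change. For compound 4 the estimate in this assay is 11000 nM, within 5000 nM to 25000 nM.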

Compound 4, half-maximal inhibitory concentration: 7150 nM
Compound 4: middle estimate off by 1.5-fold (0.19 log units), on the high side; measured number inside the range.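

Carrying the change from methyl to nitro from the core of compound 1 to the core of compound 3 gives, in this assay, steps that cannot be told apart in size: the same change on two cores in this assay, a 3.0-fold higher number (0.48 log units; beyond the scatter) from compound 1 to compound 2 and a 1.8-fold higher number (0.26 log units; within the scatter) from compound 3 to compound 4, 1.6-fold (0.22 log units) apart, within the scatter of two such steps. Taken alone, the new step, a 1.8-fold higher number from compound 3 to compound 4 (0.26 log units; within the scatter), stays within the scatter, so it does not by itself establish an effect of the change on this core. For the compounds shown here, two pairs show only that the steps on these two cores are compatible; they do not show that the change would transfer to further cores or explain either step.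

From the compounds shown here alone, what an amine or a carboxylic acid would give in place of methyl or nitro on either core stays open. Also open, going by these compounds, is the outcome of a longer chain in place of the methoxy group.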